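From Ester to Chloro on the Aromatic Ring

A few compounds are considered here, and "the series" means these few. Any claim that something is new, unique, unknown or untested is made for them only; others in the source may bear on it.

Three measured compounds carry this study: compound 1 `Cc1ccc2oc(/C=C/[S+](C)[O-])cc(=O)c2c1`, compound 2 `CC(C)C(=O)Oc1ccc2oc(/C=C/[S+](C)[O-])cc(=O)c2c1` and compound 3 `COc1ccc2c(=O)cc(/C=C/[S+](C)[O-])oc2c1`, which share one core and differ in the group on an aromatic carbon. In a functional assay on A549 cells (Homo sapiens) for cytotoxicity, with a stated time of 48 h (on this read-out higher numbers stand for weaker inhibition and lower numbers for stronger inhibition), compound 1 gives 1700 nM, compound 2 gives 2400 nM and compound 3 gives 2200 nM. Compound 2 carries the highest of the three numbers, but its gaps to compound 3 and to compound 1 both lie within the scatter, so no ranking among them can be drawn. Going by the values given here, the single direct step, a 1.4-fold higher number from compound 1 to compound 2 (0.15 log units; within the scatter), is likewise within the scatter.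

Compound 4 `C[S+]([O-])/C=C/c1cc(=O)c2cc(Cl)ccc2o1` arises from compound 2 by chloro in place of (isopropylcarbonyl)oxy on an aromatic carbon. Among the compounds with values here, only the step from compound 1 to compound 2 speaks to a swap at this place, and it was small; nothing among the measured compounds shows a substituent exchange there shifting the number beyond the scatter. The step expected in this assay is therefore a 1.2-fold lower number from compound 2 to compound 4 (0.08 log units; within the scatter). The estimate for compound 4 is 2000 nM, within 1000 nM to 4500 nM.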

Compound 4, half-maximal inhibitory concentration: 1700 nM
Estimate against measurement, compound 4: 1.2-fold (0.07 log units) above, and the stated range covers the measured number.
By their numbers in this assay, from the lowest: compounds 1, 4, 3 and 2 (each within the scatter of the next).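

In this assay, chloro, with 1 heavy atom and no hydrogen-bond acceptors, takes the place of (isopropylcarbonyl)oxy, with 6 heavy atoms and 2 hydrogen-bond acceptors, and the result is a 1.4-fold lower number from compound 2 to compound 4 (0.15 log units; within the scatter). Chloro in place of methyl gives no change at the digits printed from compound 1 to compound 4 (within the scatter), so methyl, (isopropylcarbonyl)oxy and chloro at this place in compounds 1, 2 and 4 cannot be told apart on this read-out, even across a change this large in group size and atom type. No supporting evidence is available to explain these numbers.

From the compounds shown here alone, whether an amine, a carboxylic acid or a longer alkyl chain at this place would move the number beyond the scatter remains open. The side chain on the shared core is also the same throughout, so its contribution cannot be judged from these compounds.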